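The source may hold more compounds than are shown below. What is called first, only, known or untested is meant among the compounds shown, and "the series" means these compounds.

Compound 3, with the structure `C[C@@H](c1ccc(Cl)cc1)N1Cc2cncn2C(C[C@H](O)c2ccccc2)S1(=O)=O`, gives the lowest number of the three measured compounds in an assay on isolated protein for inhibition of Aromatase (Homo sapiens), tested at 1 uM (on this read-out higher numbers stand for more inhibition at the one concentration tested (going by the name of the read-out) and lower numbers for less inhibition), where compound 3 gives 6%. Compound 1, `C[C@@H](c1ccc(Cl)cc1)N1Cc2cncn2C(CC2(C)COC2)S1(=O)=O`, gives 35% in this assay, and compound 2, `CC(C)CC1n2cncc2CN([C@H](C)c2ccc(Cl)cc2)S1(=O)=O`, gives 24%. Among the measured compounds shown here, the only measured step that touches the same position is a number 29 percentage points lower from compound 1 to compound 3 (beyond the scatter), so the hydroxy(phenyl)methyl group is tied to the lowest reading of the set.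

Compound 4, `CC(C)CC1n2cncc2CN([C@@H](C)c2ccc(Cl)cc2)S1(=O)=O`, is the unmeasured member. Relative to compound 3 the change is isopropyl in place of hydroxy(phenyl)methyl on a saturated chain carbon bound to a saturated ring carbon. This removes the very group whose arrival lowered the number in the step from compound 1 to compound 3, so a rise is the natural expectation, though the isopropyl group entering here is not the 3-methyloxetan-3-yl group of compound 1. Compound 2 carries the same isobutyl chain that compound 4 will carry and sits well below compound 1, which tempers the expected gain.

On that basis compound 4 is expected to give about 24% in this assay, with a range of 10% to 40%, which means an expected step of a number 18 percentage points higher from compound 3 to compound 4 (beyond the scatter).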

Compound 4, a percentage reported as inhibition, at one concentration (the size of the read-out at that concentration, not a potency): 56%
Compound 4: middle estimate off by 32 percentage points, on the low side, and the stated range ends below it.
By their numbers in this assay, from the lowest: compound 3; then compound 2; then compound 1; then compound 4.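

In this assay, the change at this position reaches further than the earlier step suggested: isopropyl on a saturated chain carbon bound to a saturated ring carbon gives a number 50 percentage points higher from compound 3 to compound 4 (beyond the scatter), and it also gives a number 21 percentage points higher from compound 1 to compound 4 (beyond the scatter). Among the compounds shown here, the hydroxy(phenyl)methyl group is therefore not the only group that separates these readings, since isopropyl also stands clear of 3-methyloxetan-3-yl at the same place. Isopropyl alone does not fix the reading either, since compound 2 has the same atoms and bonds yet the comparison gives a number 32 percentage points higher from compound 2 to compound 4 (beyond the scatter), and the difference between that pair is one of drawn stereochemistry: the fact that one of compounds 2 and 4 is drawn with a defined configuration and the other without, at the place where they differ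

For the compounds shown here, the saturated ring carbon carries no drawn configuration in compound 2 or compound 4, so it remains open how its configuration bears on these readings, and with only one tested concentration the readings do not give a potency. As far as these compounds go, it is also open whether a cyclopropyl group, a tert-butyl group or a longer chain such as n-butyl at this place would read like isopropyl, and whether the difference seen at the stereocentre on the saturated chain carbon would persist with those groups.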